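This account rests on a few compounds, and the source may have more. Where it says the series, first, only, none or still open, it means among the compounds named here.

Compound 1 `Cc1ccc(NS(=O)(=O)c2ccc(N3CCNC3=O)cc2)cc1`: 480 nM
Compound 2 `O=C1NCCN1c1ccc(S(=O)(=O)Nc2ccc(F)c(F)c2)cc1`: 350 nM
Compound 3 `COc1ccc(NS(=O)(=O)c2ccc(N3CCNC3=O)cc2)cc1OC`: 520 nM

In a functional assay on HT-29 cells (Homo sapiens) for antiproliferative activity, read by sulforhodamine B assay, with a stated time of 48 h (a lower number here means a stronger inhibitor, a higher number a weaker inhibitor), compound 3 sits at the upper end of these three numbers, but its gaps to compound 1 and compound 2 both fall within the usual scatter, so the three cannot be told apart. Compound 4 `COc1cccc(NS(=O)(=O)c2ccc(N3CCNC3=O)cc2)c1` differs from compound 3 in one place: hydrogen in place of methoxy on an aromatic carbon. Among the compounds with values here, the only measured step, a 1.4-fold lower number from compound 1 to compound 2 (0.14 log units; within the scatter), also changes the group on the sulfonamide nitrogen and stayed within the scatter, which suggests this part of the shared core tolerates change. No step beyond the scatter is therefore expected. Compound 4 is estimated at 500 nM, with a range from 250 nM to 1000 nM. This corresponds to an expected step of a 1.0-fold lower number from compound 3 to compound 4 (0.02 log units; within the scatter).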

Compound 4, half-maximal inhibitory concentration: 120 nM
For compound 4 the middle estimate is 4.2-fold (0.62 log units) above the measured one; the whole stated range lies above it.
By their numbers in this assay, from the lowest: compound 4; then compounds 2, 1 and 3 (each within the scatter of the next).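

In this assay, within the data shown here, removing one methoxy from the ring on the sulfonamide nitrogen gives the first step here beyond the scatter (a 4.3-fold lower number from compound 3 to compound 4 (0.64 log units; beyond the scatter)), so this position is less tolerant of change than the earlier compounds suggested. The 3-methoxyphenyl group also stands apart from 3,4-difluorophenyl (a 2.9-fold lower number from compound 2 to compound 4 (0.46 log units; beyond the scatter)) and from 4-methylphenyl (a 4.0-fold lower number from compound 1 to compound 4 (0.60 log units; beyond the scatter)). No supporting measurement is available to explain these differences. The compounds shown leave open how an amine or a longer ether chain in place of the remaining methoxy would score.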